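This account rests on a few compounds, and the source may have more. Where it says the series, first, only, none or still open, it means among the compounds named here.

Working notes on the series. Compound 1 `CC(=O)/C(=C\c1c(-c2ccccc2)[nH]c2ccccc12)S(=O)(=O)c1ccccc1` and compound 2 `O=C(/C(=C\c1c(-c2ccccc2)[nH]c2ccccc12)S(=O)(=O)c1ccccc1)c1ccccc1` share one core and differ only at the carbonyl. In a functional assay on HOP-92 cells (Homo sapiens) for inhibition, read by sulforhodamine B assay, with a stated time of 48 h (on this read-out lower numbers stand for stronger inhibition of growth and higher numbers for weaker inhibition of growth), compound 1 gives 5900 nM, and compound 2 gives 5000 nM. Among the measured compounds shown here, the single measured step in this assay, a 1.2-fold lower number from compound 1 to compound 2 (0.07 log units; within the scatter), stays within the scatter. Compound 3 `COc1ccc2[nH]c(-c3ccccc3)c(/C=C(\C#N)S(=O)(=O)c3ccccc3)c2c1` carries a nitrile at the double bond and a methoxy on the fused aromatic ring; in this assay compound 3 gives 6100 nM. Its value sits alongside those of compound 1 and compound 2, and neither gap reaches beyond the scatter, so the three measured compounds form one group on this read-out.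

Compound 4 `N#C/C(=C\c1c(-c2ccccc2)[nH]c2ccccc12)S(=O)(=O)c1ccccc1` is not yet measured. It differs from compound 3 by hydrogen in place of methoxy on an aromatic carbon. For the measured compounds named here, no measured step touches this aromatic carbon; the only step available concerns the carbonyl carbon. The three measured compounds, differing at the double bond and at the ring, lie within the scatter of one another, which gives no ground to expect a move beyond the scatter for compound 4. The step of a 1.0-fold lower number from compound 3 to compound 4 (0.01 log units; within the scatter) is therefore expected to be small. Compound 4 is estimated at 6000 nM in this assay, within a range from 3000 nM to 12000 nM.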

Compound 4, concentration for 50% growth inhibition: 10300 nM
The estimate for compound 4 lay 1.7-fold (0.23 log units) below the measured number; the measured number falls inside the stated range.
By their numbers in this assay, from the lowest: compounds 2, 1, 3 and 4 (each within the scatter of the next, the first and the last beyond it).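

At the aromatic carbon, the first change seen at this position, hydrogen in place of methoxy gives a 1.7-fold higher number from compound 3 to compound 4 (0.23 log units; within the scatter) in this assay, so the ring position shows no shift beyond the scatter. Among the compounds shown here, at the double-bonded chain carbon bound to the sulfonyl sulfur, cyano in place of benzoyl gives a 2.1-fold higher number from compound 2 to compound 4 (0.31 log units; beyond the scatter) and is the only modest step beyond the scatter, while cyano in place of acetyl gives a 1.7-fold higher number from compound 1 to compound 4 (0.24 log units; within the scatter) and stays within it. Nothing available on these compounds bears on the reason for these steps.

Going by these compounds, whether an amine or a carboxylic acid on the aromatic carbon would move the number beyond the scatter stays open. Also open, on these data alone, is how an ester or a primary amide would read at the double-bonded chain carbon.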